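Acetyl in Place of the Oxime-Type Group on the Anilide

A few compounds are considered here, and "the series" means these few. Any claim that something is new, unique, unknown or untested is made for them only; others in the source may bear on it.

Compound 1 `CCn1c(SCC(=O)Nc2ccc(/C(C)=N/O)cc2)nnc1-c1ccc(OC)c(OC)c1` is one of three compounds tested in a functional assay on the whole organism (strain albino) for inhibition, with Rattus norvegicus as the target, read by paw edema, with stated times of 30 min and 5 h, at a dose of 0.28 mmol/kg by the oral route (on this read-out higher numbers stand for more inhibition at the one dose given (going by the name of the read-out) and lower numbers for less inhibition), where compound 1 gives 73%. Compound 2 `CCn1c(SCC(=O)Nc2ccc(/C(C)=N/O)cc2)nnc1-c1ccc(OC)cc1` gives 65% and compound 3 `CCn1c(SCC(=O)Nc2ccc(/C(C)=N/O)cc2)nnc1-c1cc(OC)c(OC)c(OC)c1` gives 61%, so compound 1 stands highest of the three numbers. The step of a number 8 percentage points lower from compound 1 to compound 2 (within the scatter) comes with hydrogen in place of methoxy on an aromatic carbon, and the step of a number 12 percentage points lower from compound 1 to compound 3 (beyond the scatter) with methoxy in place of hydrogen on an aromatic carbon.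

Compound 4 `CCn1c(SCC(=O)Nc2ccc(C(C)=O)cc2)nnc1-c1ccc(OC)c(OC)c1` differs from compound 1 elsewhere: a group of 3 heavy atoms (2 carbon, 1 oxygen; no ring) in place of a group of 4 heavy atoms (2 carbon, 1 nitrogen, 1 oxygen; no ring), on an aromatic carbon. Neither measured step touches this part of the molecule; both concern methoxy groups on the other aromatic ring. For the measured compounds named here, no measured step therefore bears on this change, and the direction of the effect cannot be read from the data. On that basis compound 4 is expected to show a step of a number 8 percentage points lower from compound 1 to compound 4 (within the scatter), which is a guess of no change beyond the scatter. Compound 4 is estimated at 65% in this assay, within a range from 45% to 80%.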

Compound 4, a percentage reported as inhibition, in the whole organism at one dose (the size of the read-out at that dose, not a potency): 66%
Estimate against measurement, compound 4: 1 percentage points below; measured number inside the range.
By their numbers in this assay, from the lowest: compounds 3, 2, 4 and 1 (each within the scatter of the next, the first and the last beyond it).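

In this assay, placing acetyl on the aromatic carbon para to a large group gives a number 7 percentage points lower from compound 1 to compound 4 (within the scatter) and so does not move the number beyond the scatter. For the compounds shown here, this is the first view of this position, as the earlier compounds differ only in the methoxy groups on the other aromatic ring. In this pair, going from 1 hydrogen-bond donor in the group that leaves to 0 hydrogen-bond donors in acetyl comes with no step beyond the scatter, and nothing measured here accounts for the result.

The compounds shown leave open whether another group at this position, such as an amine or a carboxylic acid, would also stay within the scatter. They also leave open whether acetyl would do the same alongside the methoxy patterns of compound 2 and compound 3.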